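The source may hold more compounds than are shown below. What is called first, only, known or untested is meant among the compounds shown, and "the series" means these compounds.

Compound 1, `O=C(Nc1ccc(-n2ccc3nc(C(=O)NCc4ccccc4)ccc32)cc1)Nc1cccc(Cl)c1Cl`, gives > 10000 nM in an ADME assay on HS27 cells (Homo sapiens) for cytotoxicity, read by MTT assay (on this read-out lower numbers stand for stronger inhibition and higher numbers for weaker inhibition), which is a limit of the assay and not a number.
Compound 2, `COC(=O)c1ccc2c(ccn2-c2ccc(NC(=O)Nc3ccc(Cl)c(C(F)(F)F)c3)cc2)n1`, gives 8200 nM in this assay.
Compound 3, `COC(=O)c1ccc2c(ccn2-c2ccc(NC(=O)c3ccc(Cl)c(C(F)(F)F)c3)cc2)n1`, gives 2900 nM in this assay.

Among the two numbers recorded, compound 3 holds the lowest, and compound 2 sits at a higher value, a gap beyond the usual scatter. The remaining entry is compound 1, which sits at the limit of > 10000 nM in this assay, at which 1 of the 3 values shown sits.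

Compound 4, `COC(=O)c1ccc2c(ccn2-c2ccc(NC(=O)Nc3cccc(Cl)c3Cl)cc2)n1`, is not yet measured. It differs from compound 3 by (2,3-dichlorophenyl)amino in place of 4-chloro-3-(trifluoromethyl)phenyl on a carbonyl carbon, so that the amide of compound 3 becomes a urea. Among the measured compounds shown here, no measured pair differing in only this place is available, so the step must be judged from the wider picture. Compound 2, the urea with the 4-chloro-3-(trifluoromethyl)phenyl group, gives 8200 nM. Compound 1, which carries the (2,3-dichlorophenyl)amino urea on a different core, reaches only a limit of the assay. On that basis the step from compound 3 to compound 4 is expected to run towards a higher number, as a 3.1-fold higher number from compound 3 to compound 4 (0.49 log units; beyond the scatter). Compound 4 is therefore estimated at 9000 nM, within a range from 3000 nM to 30000 nM.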

Compound 4, half-maximal inhibitory concentration: > 10000 nM
Compound 4: only a limit was reported; the forecaster's own chance of this, stated with the estimate: 40%; middle value at least 1.1-fold (0.04 log units) away from the limit.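

Compound 4 gives a limit of the assay and not a number in this assay: the limit of > 10000 nM in this assay, at which 2 of the 4 values shown sit.

Placing (2,3-dichlorophenyl)amino on the carbonyl carbon in place of 4-chloro-3-(trifluoromethyl)phenyl gives an at least 3.4-fold higher number from compound 3 to compound 4 (0.53 log units; beyond the scatter), so this position does respond to this change. Among the ureas the step is an at least 1.2-fold higher number from compound 2 to compound 4 (0.08 log units; that floor lies within the scatter), which sets no firm order between the 2,3-dichlorophenyl and 4-chloro-3-(trifluoromethyl)phenyl groups on the amide-type nitrogen, and the step between compound 1 and compound 4 cannot be read.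

From the compounds shown here alone, how much of the rise belongs to the urea nitrogen and how much to the chlorine pattern stays open, and an amide carrying 2,3-dichlorophenyl would separate the two. Also open, going by these compounds, is how a carboxylic acid in place of the methoxy on the carbonyl carbon would read.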